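The compounds below may be only part of what the source reports. "The series", "measured", "known", "first", "only" and "open" are said of these compounds alone.

Measured so far:
- compound 1, `O=C(c1ccc(Cl)cc1)N1CCC(NS(=O)(=O)c2cc(S(=O)(=O)c3ccccc3)ccc2C(F)(F)F)CC1`: 1800 nM
- compound 2, `O=C(c1ccc(Cl)nc1)N1CCC(NS(=O)(=O)c2cc(S(=O)(=O)c3ccccc3)ccc2C(F)(F)F)CC1`: 140 nM

In an assay on U2OS cells for inhibition of secreted frizzled-related protein 1 (Homo sapiens), read by a luciferase reporter, with a stated time of 18 h (on this read-out higher numbers stand for an effect only at larger amounts of compound and lower numbers for an effect already at smaller amounts), compound 1 gives 1800 nM, and compound 2 gives 140 nM. For the measured compounds named here, the single measured step, a 13-fold lower number from compound 1 to compound 2 (1.11 log units; beyond the scatter), is large and beyond the scatter, so compound 2 stands lowest of the two numbers, with compound 1 as its only neighbour at a clearly higher value.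

Compound 3, `N#Cc1cccc(S(=O)(=O)N2CCC(NS(=O)(=O)c3cc(S(=O)(=O)c4ccccc4)ccc3C(F)(F)F)CC2)c1`, differs from compound 2 in one place: (3-cyanophenyl)sulfonyl in place of (6-chloropyridin-3-yl)carbonyl on an amine nitrogen in a ring. Going by the values given here, no measured step bears directly on this change. Among the compounds with values here, the only step known, a 13-fold lower number from compound 1 to compound 2 (1.11 log units; beyond the scatter), concerns the aromatic ring on the carbonyl carbon and shows that this part of the molecule can move the number strongly; compound 3 gives up the 6-chloropyridin-3-yl group that belonged to the lower number of compound 2 and brings in a sulfonyl-linked ring of a different kind. Compound 3 is therefore expected to give a higher number than compound 2, by a step of roughly a 4.3-fold higher number from compound 2 to compound 3 (0.63 log units; beyond the scatter), with wide uncertainty in either direction. For compound 3 the estimate in this assay is 600 nM, within a range from 150 nM to 3000 nM.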

Compound 3, half-maximal effective concentration: 170 nM
Estimate against measurement, compound 3: 3.5-fold (0.55 log units) above, and the stated range covers the measured number.
By their numbers in this assay, from the lowest: compounds 2 and 3 (each within the scatter of the next); then compound 1.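

In this assay, for the compounds shown here, a 1.2-fold higher number from compound 2 to compound 3 (0.08 log units; within the scatter) shows that the (6-chloropyridin-3-yl)carbonyl group is not the only group on this amine nitrogen in a ring that can give a number of this size: (3-cyanophenyl)sulfonyl, with a different link and a ring of carbon only, cannot be told apart from it. With an 11-fold lower number from compound 1 to compound 3 (1.02 log units; beyond the scatter), a large step, two quite different groups now stand clear of the (4-chlorophenyl)carbonyl group of compound 1, so neither the carbonyl link nor a pyridine ring is required among these three compounds. Nothing given here accounts for why these two groups give numbers within the scatter of each other.

The swap from compound 2 to compound 3 changes the link and the ring at once, so the contribution of the sulfonyl link cannot be separated from that of the nitrile or the ring. Still open, from the compounds shown here alone, is how (6-chloropyridin-3-yl)sulfonyl would read here, or a phenylsulfonyl group carrying an amine or a carboxylic acid in place of the nitrile.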